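From a methylphenyl amide to a thiophene amide

The source may report more compounds than this note shows. Statements on the series, on what has been measured and on what is new or still open speak of the compounds shown alone.

Of the compounds shown here, three sharing one core have been measured in an assay on LtK cells with ATP-sensitive inward rectifier potassium channel 11 (Homo sapiens) as the target; a higher number here means that more compound is needed for the effect, a lower number that less compound is needed. Compound 1 `CC(C)C(=O)Nc1c(C(O)(C(F)(F)F)C(F)(F)F)ccc2ccccc12` gives 6630 nM, compound 2 `CC(C)OC(=O)Nc1c(C(O)(C(F)(F)F)C(F)(F)F)ccc2ccccc12` gives 1160 nM, and compound 3 `Cc1cccc(C(=O)Nc2c(C(O)(C(F)(F)F)C(F)(F)F)ccc3ccccc23)c1` gives 23 nM, the lowest of the three numbers. The steps leading to compound 3 were a 290-fold lower number from compound 1 to compound 3 (2.46 log units; beyond the scatter) and a 50-fold lower number from compound 2 to compound 3 (1.70 log units; beyond the scatter), so putting an aromatic ring on the carbonyl carbon in place of isopropyl or isopropoxy brought large gains. Compound 4 `O=C(Nc1c(C(O)(C(F)(F)F)C(F)(F)F)ccc2ccccc12)c1cccs1` changes the same place again: thiophen-2-yl in place of 3-methylphenyl on a carbonyl carbon. Among the compounds with values here, no measured step swaps one aromatic ring for another, so the earlier steps only show that an aromatic ring there is favoured. For compound 4 the expected step is a 2.2-fold higher number from compound 3 to compound 4 (0.34 log units; beyond the scatter), uncertain in direction. Compound 4 is therefore estimated at 50 nM, within 12 nM to 200 nM.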

Compound 4, half-maximal effective concentration: 12 nM
The estimate for compound 4 lay 4.2-fold (0.62 log units) above the measured number, within the range that was stated.
By their numbers in this assay, from the lowest: compounds 4 and 3 (each within the scatter of the next); then compound 2; then compound 1.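

Swapping one aromatic ring for another on the carbonyl carbon changes little, with thiophen-2-yl in place of 3-methylphenyl giving (a 1.9-fold lower number from compound 3 to compound 4 (0.28 log units; within the scatter)), so a six-membered ring of carbon only is not required. The large steps from the non-aromatic groups hold for this ring too, with a 97-fold lower number from compound 2 to compound 4 (1.99 log units; beyond the scatter) and a 550-fold lower number from compound 1 to compound 4 (2.74 log units; beyond the scatter) in this assay, so the gain is not tied to 3-methylphenyl alone. Nothing available explains why these rings give such low numbers. On these data alone, whether a pyridine ring, or a phenyl ring bearing a carboxylic acid, would give a similar number stays open.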